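From 2-Fluorobenzyl to 2-Chloro-4-fluorobenzyl on a Shared Core

This account rests on a few compounds, and the source may have more. Where it says the series, first, only, none or still open, it means among the compounds named here.

Measured compounds:
Compound 1 `O=c1c2cnn(-c3ccc(F)cc3)c2ncn1CC1(O)CCN(Cc2ccccc2F)CC1` gives 9800 nM
Compound 2 `O=c1c2cnn(-c3ccc(F)cc3)c2ncn1CC1(O)CCN(Cc2cccc(Cl)c2)CC1` gives "not determined" (no result reported)
Compound 3 `O=c1c2cnn(-c3ccc(F)cc3)c2ncn1CC1(O)CCN(Cc2ccc(Br)cc2)CC1` gives 6700 nM

All three were tested in an assay on Sf21 cells for inhibition of ubiquitin carboxyl-terminal hydrolase 7 (Homo sapiens), read by spectrophotometry, with stated times of 30 min and 2 h; on this read-out lower numbers stand for stronger inhibition and higher numbers for weaker inhibition. On the two numbers available, compound 1 stands highest, with compound 3 close by and within the usual scatter. Compound 4 `O=c1c2cnn(-c3ccc(F)cc3)c2ncn1CC1(O)CCN(Cc2ccc(F)cc2Cl)CC1` differs from compound 1 in one place: 2-chloro-4-fluorophenyl in place of 2-fluorophenyl on a saturated chain carbon bound to an amine nitrogen in a ring. Among the measured compounds shown here, the only measured step touching this same phenyl group is a 1.5-fold lower number from compound 1 to compound 3 (0.17 log units; within the scatter), a move that does not exceed the scatter, so no clear shift is expected here either, and a slight lowering at most. Compound 4 is therefore estimated at 7000 nM, with a likely range from 3000 nM to 18000 nM, which amounts to an expected 1.4-fold lower number from compound 1 to compound 4 (0.15 log units; within the scatter).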

Compound 4, half-maximal inhibitory concentration: 1600 nM
Compound 4: middle estimate off by 4.4-fold (0.64 log units), on the high side, outside the stated range (below it).
By their numbers in this assay, from the lowest: compound 4; then compounds 3 and 1 (each within the scatter of the next).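

Among the compounds shown here, compound 4 gives the first change at this position that clearly exceeds the scatter, with a 6.1-fold lower number from compound 1 to compound 4 (0.79 log units; beyond the scatter) and a 4.2-fold lower number from compound 3 to compound 4 (0.62 log units; beyond the scatter). The group on this saturated chain carbon can therefore shift the number measurably, which the earlier comparison of compound 1 and compound 3 did not show. Nothing measured here explains why this particular group has that effect. The compounds shown leave open whether the chlorine or the fluorine of the new group matters more. They also leave open how a phenyl group carrying a methoxy group or a nitrile would compare.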